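The source may hold more compounds than are shown below. What is called first, only, known or untested is meant among the compounds shown, and "the series" means these compounds.

Compound 3 `COC(=O)c1cccc(NC(=O)C2(C(=O)Nc3ccc(Nc4ncc5cc(C(=O)N(C)C)n(C6CCCC6)c5n4)cc3)CC2)c1` is one of three measured compounds built on a shared core. The other two are compound 1 `CN(C)C(=O)c1cc2cnc(Nc3ccc(NC(=O)C4(C(=O)Nc5ccc(Br)cc5)CC4)cc3)nc2n1C1CCCC1` and compound 2 `COC(=O)c1ccc(NC(=O)C2(C(=O)Nc3ccc(Nc4ncc5cc(C(=O)N(C)C)n(C6CCCC6)c5n4)cc3)CC2)cc1`. In a functional assay on A549 cells (Homo sapiens) for inhibition, read by CCK-8 assay, with a stated time of 72 h, tested at 10 uM (a lower number here means less inhibition of growth, a higher number more inhibition of growth at the concentration tested), compound 3 gives 91%. In this assay compound 1 gives 90.3%, and compound 2 gives 92%. Compound 3 therefore sits in the middle of a very narrow band, since a number 0.7 percentage points higher from compound 1 to compound 3 (within the scatter) and a number 1 percentage points lower from compound 2 to compound 3 (within the scatter) both fall inside the scatter; on these numbers the three compounds cannot be told apart.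

Compound 4 `CN(C)C(=O)c1cc2cnc(Nc3ccc(NC(=O)C4(C(=O)Nc5cccc(C#N)c5)CC4)cc3)nc2n1C1CCCC1` differs from compound 3 in a single place: cyano in place of methoxycarbonyl on an aromatic carbon. The measured steps that bear on this are the ones that also change the group on that outer six-membered ring. There, a number 1.7 percentage points higher from compound 1 to compound 2 (within the scatter) swapped bromo for methoxycarbonyl, and a number 1 percentage points lower from compound 2 to compound 3 (within the scatter) moved the methoxycarbonyl to the carbon meta to the large group; neither moved the read-out beyond the scatter. A third exchange on the same ring, methoxycarbonyl to cyano, is therefore expected to behave alike, giving a number 1 percentage points lower from compound 3 to compound 4 (within the scatter), a step of no real size in either direction. For compound 4 the estimated value is 90%, with a range from 82% to 96%.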

Compound 4, percent growth inhibition at one concentration: 73.6%
Compound 4: middle estimate off by 16.4 percentage points, on the high side; measured number outside the range, below it.
By their numbers in this assay, from the lowest: compound 4; then compounds 1, 3 and 2 (each within the scatter of the next).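

Among the compounds shown here, the outer ring had looked indifferent to what it carried, but it is not: with the group meta to a large group, exchanging methoxycarbonyl for cyano gives the first change here that clears the scatter in this assay (a number 17.4 percentage points lower from compound 3 to compound 4 (beyond the scatter)). The 3-cyanophenyl compound also stands apart from the other two (a number 18.4 percentage points lower from compound 2 to compound 4 (beyond the scatter); a number 16.7 percentage points lower from compound 1 to compound 4 (beyond the scatter)), so bromo and both placements of methoxycarbonyl keep the read-out together while this one group does not, although those two steps change the place on the ring as well as the group. Nothing measured here explains why this exchange lowers the read-out.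

The compounds shown leave open whether the fall belongs to cyano itself or to cyano at this place, a question that 4-cyanophenyl on the same amide nitrogen would address. They also leave open how other groups at this place would behave, such as a carboxylic acid, a primary amide or an aminomethyl group, and so whether methoxycarbonyl or cyano is the exception on this ring.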